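Swapping Methyl for Methoxyphenyl on the Hydroxyl-Bearing Carbon

The compounds below may be only part of what the source reports. "The series", "measured", "known", "first", "only" and "open" are said of these compounds alone.

Compound 3 `CC(O)CCn1nc2c(Br)c(Br)c(Br)c(Br)c2n1` stands lowest of the three measured numbers in a functional assay on MCF7 cells (Homo sapiens) for antiproliferative activity, read by MTT assay, with a stated time of 48 h, tested at 12.5 uM (on this read-out higher numbers stand for a weaker effect at the one concentration tested and lower numbers for a stronger effect), giving 79%. Compound 1 `OCC(O)Cn1nc2c(Br)c(Br)c(Br)c(Br)c2n1` gives 116%, and compound 2 `OC(CCn1nc2c(Br)c(Br)c(Br)c(Br)c2n1)c1cccc(Cl)c1` gives 107%. Compound 4 `COc1cccc(C(O)CCn2nc3c(Br)c(Br)c(Br)c(Br)c3n2)c1` differs from compound 3 by 3-methoxyphenyl in place of methyl on a saturated chain carbon bound to an oxygen on a saturated carbon and a saturated chain carbon. The step of a number 28 percentage points lower from compound 2 to compound 3 (beyond the scatter) bears most directly on this change, since it also exchanged methyl for a substituted phenyl on the same carbon; the step of a number 37 percentage points lower from compound 1 to compound 3 (beyond the scatter) concerns a different part of the chain and says less. Returning an aromatic ring to this position is therefore expected to raise the number again, and a rise of similar size is expected, a number 23 percentage points higher from compound 3 to compound 4 (beyond the scatter). Compound 4 is estimated to give 102%, with a range from 82% to 122%.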

Compound 4, a percentage reported as activity, at one concentration (the size of the read-out at that concentration, not a potency): 97%
Compound 4: middle estimate off by 5 percentage points, on the high side; the range from low to high includes it.
By their numbers in this assay, from the lowest: compound 3; then compounds 4, 2 and 1 (each within the scatter of the next, the first and the last beyond it).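

In this assay, the step of a number 18 percentage points higher from compound 3 to compound 4 (beyond the scatter) shows that the methyl compound's stronger effect holds against a second substituted phenyl at this carbon, not only against 3-chlorophenyl. The step of a number 10 percentage points lower from compound 2 to compound 4 (within the scatter) adds that methoxy in place of chloro on an aromatic carbon moves the number no further than the usual scatter, so these two substituents cannot be told apart here. Nothing available explains either step. Still open, going by these compounds, is where a plain phenyl ring, an amine on that ring, or a longer chain in place of methyl would fall.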